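Two-Carbon Link to a 4-Methoxyphenyl Group in Place of a Biaryl

The source may hold more compounds than are shown below. What is called first, only, known or untested is meant among the compounds shown, and "the series" means these compounds.

Compound 1 `CCCCCCCCS(=O)(=O)Nc1ccc(-c2ccccc2OC)cc1C(=O)O`: 27600 nM
Compound 2 `CCCCCCCCS(=O)(=O)Nc1ccc(C(=O)c2ccc(-c3ccccc3)cc2)cc1C(=O)O`: 13000 nM
Compound 3 `CCCCCCCCS(=O)(=O)Nc1cc(/C=C/c2ccc(OC)cc2)ccc1C(=O)O`: 38700 nM

In an assay on mitochondria (strain BALB/c) for inhibition of glycerol-3-phosphate acyltransferase 1, mitochondrial (Mus musculus), read by scintillation counting, with a stated time of 10 min (a higher number here means a weaker inhibitor, a lower number a stronger inhibitor), compound 1 gives 27600 nM, the second highest of the three numbers. Compound 3 sits nearest to it, within the scatter; compound 2 sits furthest, with a lower number by a margin beyond the scatter. Compound 4 `CCCCCCCCS(=O)(=O)Nc1ccc(CCc2ccc(OC)cc2)cc1C(=O)O` has not been measured. It differs from compound 1 in one place: 2-(4-methoxyphenyl)ethyl in place of 2-methoxyphenyl on an aromatic carbon. Within the data shown here, no step between measured compounds shows the effect of this change directly, so the expectation rests on the level of the three known numbers, all of them high. The expected step in this assay is estimated as small, within the scatter, as a 1.1-fold higher number from compound 1 to compound 4 (0.04 log units; within the scatter) expresses. Compound 4 is estimated at 30000 nM, with a range from 12000 nM to 80000 nM.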

Compound 4, half-maximal inhibitory concentration: 26300 nM
The estimate for compound 4 lay 1.1-fold (0.06 log units) above the measured number; the measured number falls inside the stated range.
By their numbers in this assay, from the lowest: compound 2; then compounds 4, 1 and 3 (each within the scatter of the next).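

In this assay, among these compounds, putting 2-(4-methoxyphenyl)ethyl in place of 2-methoxyphenyl gives a 1.0-fold lower number from compound 1 to compound 4 (0.02 log units; within the scatter) at this aromatic carbon, the first step that can be read at this position. The larger group thus leaves the number as high as it was, with no shift beyond the scatter. No measurement offers an explanation for this result. Still open, from the compounds shown here alone, is whether an amine or a carboxylic acid in place of the methoxy group, or a longer chain as the link, would move the number beyond the scatter.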